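The source may report more compounds than this note shows. Statements on the series, on what has been measured and on what is new or still open speak of the compounds shown alone.

Working notes on the adenosine amide series at an assay on cell membranes for binding affinity to 2-oxoglutarate receptor 1 (Rattus norvegicus), read by radioligand binding; on this read-out lower numbers stand for stronger inhibition and higher numbers for weaker inhibition. Compound 1 `NCCCCCCCCNC(=O)[C@H]1OC(n2cnc3c(N)ncnc32)[C@H](O)[C@@H]1O` gives 29 nM. Compound 2 `Nc1ncnc2c1ncn2C1O[C@H](C(=O)NC2CCCCCC2)[C@@H](O)[C@H]1O` gives 22 nM, and compound 3 `Nc1ncnc2c1ncn2C1O[C@H](C(=O)NC2CCCCCCC2)[C@@H](O)[C@H]1O` gives 23 nM. Compound 3 thus stands second highest of the three numbers, nearest to compound 2 and furthest from compound 1, with both gaps within the scatter. The three measured steps, a 1.3-fold lower number from compound 1 to compound 2 (0.12 log units; within the scatter), a 1.3-fold lower number from compound 1 to compound 3 (0.10 log units; within the scatter) and a 1.0-fold higher number from compound 2 to compound 3 (0.02 log units; within the scatter), all exchange one carbon group for another on the amide-type nitrogen and none of them moves this assay beyond the scatter.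

Compound 4 `CC(C)CONC(=O)[C@H]1OC(n2cnc3c(N)ncnc32)[C@H](O)[C@@H]1O` carries the change (isobutoxy in place of cyclooctyl on an amide-type nitrogen). Going by the values given here, no measured step introduces an oxygen on the amide-type nitrogen, so the bearing of the three steps is indirect: they show only that the group on this nitrogen can vary among carbon chains and rings without a shift beyond the scatter. For compound 4 a weaker number is expected, with the step of a 2.6-fold higher number from compound 3 to compound 4 (0.42 log units; beyond the scatter), since the change goes outside what the measured steps cover. The estimate for compound 4 in this assay is 60 nM, in the range 20 nM to 200 nM.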

Compound 4, inhibition constant: 20 nM
Beside the measured number, compound 4's estimate is 3.0-fold (0.48 log units) above it; low and high end bracket the measured number.
By their numbers in this assay, from the lowest: compounds 4, 2, 3 and 1 (each within the scatter of the next).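

In this assay the amide-type nitrogen now also carries an oxygen-linked group, and isobutoxy in place of cyclooctyl gives (a 1.2-fold lower number from compound 3 to compound 4 (0.06 log units; within the scatter)). The steps to the other two groups read the same way, isobutoxy in place of cycloheptyl (a 1.1-fold lower number from compound 2 to compound 4 (0.04 log units; within the scatter)) and isobutoxy in place of 8-aminooctyl (a 1.5-fold lower number from compound 1 to compound 4 (0.16 log units; within the scatter)). This position therefore accepts a group with no ring, 5 heavy atoms rather than 8 and one hydrogen-bond acceptor rather than none, with no step beyond the scatter among the four compounds.

No supporting evidence bears on this result. The compounds shown leave open whether a methyl group, a benzyloxy group or a chain ending in a carboxylic acid on the amide-type nitrogen would also stay within the scatter.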